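Imidazolyl replacement at the aryl position of compound 1

This account rests on a few compounds, and the source may have more. Where it says the series, first, only, none or still open, it means among the compounds named here.

Compound 1 `c1cncc(-c2ccccc2OCC2=NCCN2)c1` is the reference point of this small series. In a functional assay for activation of Alpha-1D adrenergic receptor (Homo sapiens), read by calcium flux (on this read-out lower numbers stand for an effect already at smaller amounts and higher numbers for an effect only at larger amounts of compound), compound 1 gives 158 nM, the highest of the two readable numbers. Compound 3 `c1ccc(-c2ccoc2)c(OCC2=NCCN2)c1` carries a furan-3-yl in place of the pyridin-3-yl and in this assay compound 3 gives 5.01 nM; the step of a 32-fold lower number from compound 1 to compound 3 (1.50 log units; beyond the scatter) is the one clear movement in the set. Compound 2 `c1ccc(-c2cnccn2)c(OCC2=NCCN2)c1` carries a pyrazin-2-yl; in this assay compound 2 is reported only as a limit, < 100000 nM, so the step that the limit leaves unreadable from compound 1 to compound 2 cannot be sized, as recorded in the limit of < 100000 nM in this assay, at which 1 of the 3 values shown sits.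

Compound 4 `c1ccc(-c2ncc[nH]2)c(OCC2=NCCN2)c1` is not yet measured. It differs from compound 1 by 1H-imidazol-2-yl in place of pyridin-3-yl on an aromatic carbon. Among the compounds with values here, the only readable precedent for exchanging the six-membered heteroaryl for a five-membered one is the step from compound 1 to compound 3, which was large and toward lower numbers; the unreadable step to compound 2 warns that an attachment through the ring carbon next to two ring nitrogens need not follow. For compound 4 the expectation in this assay is therefore a moderate move toward lower numbers, a 2.6-fold lower number from compound 1 to compound 4 (0.42 log units; beyond the scatter), with a wide range, giving an estimated value of 60 nM between 8 nM and 500 nM.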

Compound 4, half-maximal effective concentration: < 100000 nM
Compound 4 was reported as a limit; the forecaster's own chance of this, stated with the estimate: 10%; the middle value is on the limit's open side.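

Within the data shown here, compound 4 is reported only as a limit, and no step to it from compound 1, compound 2 or compound 3 can be read: the limit of < 100000 nM in this assay, at which 2 of the 4 values shown sit. The compounds shown leave open how far compound 2 and compound 4 actually lie from compound 1.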